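Iodo in place of fluoro on compound 3

The compounds below may be only part of what the source reports. "The series", "measured", "known", "first", "only" and "open" are said of these compounds alone.

Measured in a functional assay on MDA-MB-468 cells (Homo sapiens) for antiproliferative activity (on this read-out lower numbers stand for stronger inhibition of growth and higher numbers for weaker inhibition of growth), so far:
compound 1 `Cc1cc(-c2nc3ccccc3s2)ccc1N` gives < 0.1 nM (a limit of the assay, not a number)
compound 2 `COc1ccc(-c2nc3ccccc3s2)cc1OC` gives 530 nM
compound 3 `COc1ccc(-c2nc3cc(F)ccc3s2)cc1F` gives 640 nM

Compound 3 stands at 640 nM and compound 2 stands at 530 nM within the scatter of each other.

Compound 4 `COc1ccc(-c2nc3cc(F)ccc3s2)cc1I` carries iodo in place of fluoro on an aromatic carbon, ortho to a methoxy group iodo in place of fluoro on an aromatic carbon and meta to a large group. For the measured compounds named here, no measured pair isolates this change. In this assay a moderate step towards stronger inhibition is expected, though a step within the scatter remains possible. The expected change is a 3.2-fold lower number from compound 3 to compound 4 (0.51 log units; beyond the scatter) and its size is uncertain. Compound 4 is estimated at 200 nM with an expected range of 10 nM to 1500 nM in this read-out.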

Compound 4, concentration for 50% growth inhibition: 360 nM
Beside the measured number, compound 4's estimate is 1.8-fold (0.26 log units) below it; low and high end bracket the measured number.
By their numbers in this assay, from the lowest: compounds 4, 2 and 3 (each within the scatter of the next). At a limit, below all of these: compound 1.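

In this assay, for the compounds shown here, the first single-place step is a 1.8-fold lower number from compound 3 to compound 4 (0.25 log units; within the scatter), so at this position, ortho to a methoxy group, iodo in place of fluoro gives no difference beyond the scatter. Fluoro and iodo can therefore be treated as equivalent here on this read-out, for this one pair only. Nothing measured here bears on why the exchange leaves the number within the scatter.

Still open, from the compounds shown here alone, is whether a nitrile or a carboxylic acid at this position would move the number. Going by these compounds alone, also open is what the fluoro on the shared core contributes, as no pair isolates it.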